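Trimming the Amide Substituent of Compound 2

This account rests on a few compounds, and the source may have more. Where it says the series, first, only, none or still open, it means among the compounds named here.

Going by the values given here, in a functional assay on PC-3 cells (Homo sapiens) for antiproliferative activity, read by MTT assay, with a stated time of 48 h (a lower number here means a stronger inhibitor, a higher number a weaker inhibitor), compound 2 `CCOC(=O)C(CC(=O)OC)NC(=O)c1ccc(C(CC)(CC)c2ccc(OCCC(O)(CC)CC)c(C)c2)n1CC` gives 5840 nM, the lower of the two numbers measured so far, while compound 1 `C=CCN(C)C(=O)c1ccc(C(CC)(CC)c2ccc(OCCC(O)(CC)CC)c(C)c2)n1CC` gives 12800 nM. Compound 3 `CCn1c(C(=O)NC(C)CO)ccc1C(CC)(CC)c1ccc(OCCC(O)(CC)CC)c(C)c1` keeps the shared core but carries 1-(hydroxymethyl)ethyl on the amide-type nitrogen, and the change from compound 2 is a group of 4 heavy atoms (3 carbon, 1 oxygen; no ring) in place of a group of 11 heavy atoms (7 carbon, 4 oxygen; no ring), on an amide-type nitrogen.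

Among the compounds with values here, only one measured step bears on this change: a 2.2-fold lower number from compound 1 to compound 2 (0.34 log units; beyond the scatter). There the larger group went with the lower number, so a smaller group may give back a little of that gain. This is thin evidence, since it is a single step and the new group matches neither earlier one. In this assay the expected change is therefore modest and towards a higher number, with the estimated step being a 1.4-fold higher number from compound 2 to compound 3 (0.14 log units; within the scatter). For compound 3 the estimated value is 8000 nM, with an expected range from 3000 nM to 20000 nM.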

Compound 3, half-maximal inhibitory concentration: 7870 nM
Beside the measured number, compound 3's estimate is 1.0-fold (0.01 log units) above it, and the stated range covers the measured number.
By their numbers in this assay, from the lowest: compounds 2, 3 and 1 (each within the scatter of the next, the first and the last beyond it).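

With the group of 11 heavy atoms on the amide-type nitrogen replaced by 1-(hydroxymethyl)ethyl, this assay shows a 1.3-fold higher number from compound 2 to compound 3 (0.13 log units; within the scatter), so far fewer heavy atoms here need not cost a measurable loss. Compared on the carbonyl carbon, (1-(hydroxymethyl)ethyl)amino in place of allyl(methyl)amino gives a 1.6-fold lower number from compound 1 to compound 3 (0.21 log units; within the scatter), so compound 3 cannot be separated from either neighbour, even though a 2.2-fold lower number from compound 1 to compound 2 (0.34 log units; beyond the scatter) stands beyond the scatter, and group size alone does not sort these three compounds. No measurement available here accounts for these results.

On these data alone, whether the hydroxyl of 1-(hydroxymethyl)ethyl contributes at all remains open, and a plain propyl group at this place would test that. Also open, as far as these compounds go, is whether an amine, a carboxylic acid or a longer chain here could move the number beyond the scatter from compound 2.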